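The compounds below may be only part of what the source reports. "The series", "measured", "known", "first", "only" and "open" are said of these compounds alone.

Compound 1, `Cc1ccc(CCCN2CCc3nc(C)c([C@H](OC(C)(C)C)C(=O)O)c(-c4cc(F)c5c(c4C)CCCO5)c3C2)cc1F`: > 40000 nM
Compound 2, `Cc1ccc(-c2c3c(nc(C)c2[C@H](OC(C)(C)C)C(=O)O)CCN(Cc2ccccc2)C3)cc1`: > 40000 nM

Both measured compounds were examined in an ADME assay on MT2 cells (Homo sapiens) for cytotoxicity, read by XTT assay, with a stated time of 4 days; on this read-out lower numbers stand for higher toxicity in this test and higher numbers for lower toxicity in this test. Compound 1 gives > 40000 nM, which is a limit of the measurement rather than a number. Compound 2 likewise gives only a limit, > 40000 nM. Where compound 1 stands can therefore only be described as sitting at the limit of > 40000 nM in this assay, at which 2 of the 2 values shown sit. The compound still to be measured is compound 3, `Cc1nc2c(c(-c3cc(F)c4c(c3C)CCCO4)c1[C@H](OC(C)(C)C)C(=O)O)CN(CCCc1ccccc1)CC2`. It differs from compound 1 by phenyl in place of 3-fluoro-4-methylphenyl on a saturated chain carbon, three bonds along the chain from an amine nitrogen in a ring. Among the compounds with values here, no measured pair of compounds differs in one place only, so no measured step guides this change. The step that the limit leaves unreadable from compound 1 to compound 3 is expected to be small, none beyond the scatter and in no clear direction, because compound 1 already sits at the limit of > 40000 nM in this assay, at which 2 of the 2 values shown sit. Compound 3 is expected to give about 60000 nM in this assay, between 25000 nM and 200000 nM, most likely reported again only as a limit.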

Compound 3, half-maximal cytotoxic concentration: > 40000 nM
Compound 3 ended at the assay's limit; the forecaster's own chance of this, stated with the estimate: 80%; the middle value lies beyond the limit too.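

No step can be read from compound 1 to compound 3 in this assay, because both values are limits and not numbers: the limit of > 40000 nM in this assay, at which 3 of the 3 values shown sit.

The compounds shown leave open whether phenyl in place of 3-fluoro-4-methylphenyl alters this read-out at all, and what actual number any of the three would give.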